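Replacing the hydroxyphenyl arm of compound 2 with thiazole

The source may report more compounds than this note shows. Statements on the series, on what has been measured and on what is new or still open speak of the compounds shown alone.

Measured so far:
Compound 1 `Cc1csc(-c2ncnc3c2ncn3C2O[C@H](CO)[C@@H](O)[C@H]2O)n1`: 6000 nM
Compound 2 `OC[C@H]1OC(n2cnc3c(-c4ccc(O)cc4)ncnc32)[C@H](O)[C@@H]1O`: 1250 nM

Both compounds share one core and were tested in a functional assay on CCRF-CEM cells (Homo sapiens) for inhibition; on this read-out lower numbers stand for stronger inhibition and higher numbers for weaker inhibition. Going by the values given here, compound 2 stands lowest of the two numbers; its only neighbour is compound 1, and the one step measured, a 4.8-fold lower number from compound 1 to compound 2 (0.68 log units; beyond the scatter), shows that putting 4-hydroxyphenyl where 4-methyl-1,3-thiazol-2-yl had been lowered the number modestly.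

Compound 3 `OC[C@H]1OC(n2cnc3c(-c4nccs4)ncnc32)[C@H](O)[C@@H]1O` is not yet measured. Its change from compound 2 is 1,3-thiazol-2-yl in place of 4-hydroxyphenyl on an aromatic carbon. This is close to a reversal of the measured step: a thiazolyl ring comes back, now without the methyl that compound 1 carries. Among the compounds with values here, the step of a 4.8-fold lower number from compound 1 to compound 2 (0.68 log units; beyond the scatter) is the only guide, and it points the other way, so the number is expected to rise again toward that of compound 1. Compound 3 is expected to show a step of a 3.2-fold higher number from compound 2 to compound 3 (0.51 log units; beyond the scatter). Compound 3 is estimated at 4000 nM, within a range of 1500 nM to 12000 nM.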

Compound 3, half-maximal inhibitory concentration: 2730 nM
Estimate against measurement, compound 3: 1.5-fold (0.17 log units) above; the range from low to high includes it.
By their numbers in this assay, from the lowest: compound 2; then compound 3; then compound 1.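

In this assay, the position on the aromatic carbon responds to the ring type even without the methyl, since 1,3-thiazol-2-yl in place of 4-hydroxyphenyl gives a modest rise (a 2.2-fold higher number from compound 2 to compound 3 (0.34 log units; beyond the scatter)). The new compound also separates two changes that the first step had combined: removing only the methyl from the thiazole ring gives a modest fall (a 2.2-fold lower number from compound 1 to compound 3 (0.34 log units; beyond the scatter)). The gap between the two earlier compounds therefore divides into a methyl part and a ring part, and nothing measured here explains either one.

From the compounds shown here alone, it remains open whether the advantage of 4-hydroxyphenyl comes from its hydroxyl or from the six-membered ring itself. A plain phenyl or a 4-aminophenyl group at this position would help separate those two possibilities.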